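The source may hold more compounds than are shown below. What is called first, only, known or untested is meant among the compounds shown, and "the series" means these compounds.

Working notes on the series. Compound 1 `COc1cccc(-c2ccc(C(=O)N(Cc3cccc(OCCCCCC(=O)O)c3)C(C)C)cc2)c1` is the starting point in an ADME assay on HEK293 cells (Homo sapiens) for cytotoxicity, read by CellTiter-Glo and resazurin assay, with a stated time of 72 h; on this read-out lower numbers stand for an effect already at smaller amounts and higher numbers for an effect only at larger amounts of compound. In this assay compound 1 reaches only a limit, > 20900 nM, and no number. Compound 2 `CC(C)N(Cc1cccc(OCCCCCC(=O)O)c1)C(=O)c1ccc(-c2cccc(OC(F)(F)F)c2)cc1` carries trifluoromethyl in place of methyl on an oxygen on an aromatic ring. In this assay compound 2 likewise stops at a limit, > 26000 nM. The step that the two limits leave unreadable from compound 1 to compound 2 cannot be read, since both ends rest on the limit of > 20900 nM in this assay, at which 1 of the 2 values shown sits, and (the limit of > 26000 nM in this assay, at which 1 of the 2 values shown sits). Compound 3 `CC(C)N(Cc1cccc(OCCCCCC(=O)O)c1)C(=O)c1ccc(-c2cccc(F)c2)cc1` differs from compound 1 by fluoro in place of methoxy on an aromatic carbon. No measured step in the set bears a readable size, so nothing among the shown numbers sets a direction for this change; the two measured compounds simply sit at limits. For compound 3 in this assay the expected step that the limit leaves unreadable from compound 1 to compound 3 is none beyond the scatter, with a limit again the likely outcome. The estimate for compound 3 in this assay is 30000 nM, within 15000 nM to 60000 nM.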

Compound 3, half-maximal effective concentration: > 26000 nM
Compound 3: a limit, no number; the forecaster's own chance of this, stated with the estimate: 85%; the middle value does not contradict the limit.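

In this assay compound 3 also stops at a limit, > 26000 nM, and neither step to it, from compound 1 or from compound 2, can be read. The compounds shown leave open whether methoxy, trifluoromethoxy or fluoro at this place makes any difference to the read-out.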